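A dimethoxybenzyl variant of a bis(trifluoromethyl)benzenesulfonamide

A few compounds are considered here, and "the series" means these few. Any claim that something is new, unique, unknown or untested is made for them only; others in the source may bear on it.

Measured so far in a functional assay on MCF7 cells (Homo sapiens) for inhibition, read by MTT assay, with a stated time of 72 h; a higher number here means a weaker inhibitor of growth, a lower number a stronger inhibitor of growth:
Compound 1 `O=S(=O)(NCCCNCc1ccccc1Cl)c1cc(C(F)(F)F)cc(C(F)(F)F)c1` gives 8800 nM.
Compound 2 `O=S(=O)(NCCNCc1ccc(-c2ccccc2)cc1)c1cc(C(F)(F)F)cc(C(F)(F)F)c1` gives 1400 nM.
Compound 3 `O=S(=O)(NCCCCNCc1ccc(Br)cc1)c1cc(C(F)(F)F)cc(C(F)(F)F)c1` gives 1500 nM.

Compound 1 stands highest of the three numbers; compound 3 is its nearest neighbour and compound 2 lies a little further down. Compound 4 `COc1ccc(CNCCCNS(=O)(=O)c2cc(C(F)(F)F)cc(C(F)(F)F)c2)cc1OC` arises from compound 1 by 3,4-dimethoxyphenyl in place of 2-chlorophenyl on a saturated chain carbon bound to an amine nitrogen. Among the measured compounds shown here, one measured step touches the same place: a 5.9-fold lower number from compound 1 to compound 3 (0.77 log units; beyond the scatter), although that step also lengthened the chain, so it guides only loosely. For the measured compounds named here, no measured compound carries a methoxy group, and nothing here tells how two of them behave. The estimate for compound 4 is therefore expected to sit modestly below compound 1, at 4000 nM with a range from 1500 nM to 12000 nM. That expectation corresponds to a step of a 2.2-fold lower number from compound 1 to compound 4 (0.34 log units; beyond the scatter).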

Compound 4, concentration for 50% growth inhibition: 1900 nM
Compound 4: the middle estimate sits 2.1-fold (0.32 log units) above what was measured; the range from low to high includes it.
By their numbers in this assay, from the lowest: compounds 2, 3 and 4 (each within the scatter of the next); then compound 1.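

With the chain held as in compound 1, replacing 2-chlorophenyl with 3,4-dimethoxyphenyl gives a 4.6-fold lower number from compound 1 to compound 4 (0.67 log units; beyond the scatter) in this assay. Unlike the earlier step at this place, this one leaves the chain unchanged, so a change of the aromatic group alone moves the number beyond the scatter. No evidence is available that explains this shift.

The compounds shown leave open whether losing the chlorine or gaining the methoxy groups accounts for the step. A plain phenyl or a phenyl carrying a single methoxy group would separate these two readings.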